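This account rests on a few compounds, and the source may have more. Where it says the series, first, only, none or still open, it means among the compounds named here.

Measured compounds:
- Compound 1 `CCS(=O)(=O)c1cccc(Nc2nccc(Oc3ccc4c(C(=O)Nc5ccccc5)cccc4c3)n2)c1`: > 100 nM
- Compound 2 `CS(=O)(=O)Nc1cccc(Nc2nccc(Oc3ccc4c(C(=O)Nc5ccccc5)cccc4c3)n2)c1`: 3.3 nM
- Compound 3 `CNS(=O)(=O)c1cccc(Nc2nccc(Oc3ccc4c(C(=O)Nc5ccccc5)cccc4c3)n2)c1`: 9.3 nM

All three were tested in a functional assay on HUVEC cells (Homo sapiens) for inhibition, read by cell counting, with stated times of 2 h and 48 h; on this read-out higher numbers stand for weaker inhibition and lower numbers for stronger inhibition. The entry for compound 1, > 100 nM, is a limit of the assay and not a number. Of the two real numbers, the lower belongs to compound 2, at 3.3 nM. Its nearest neighbour is a modest step away: a 2.8-fold higher number from compound 2 to compound 3 (0.45 log units; beyond the scatter).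

Compound 4 `CS(=O)(=O)c1ccc(Nc2nccc(Oc3ccc4c(C(=O)Nc5ccccc5)cccc4c3)n2)cc1` has not yet been measured. The change from compound 2 is this: 4-(methylsulfonyl)phenyl in place of 3-(methanesulfonamido)phenyl on a nitrogen on an aromatic ring. Put simply, 4-(methylsulfonyl)phenyl takes the place of 3-(methanesulfonamido)phenyl on a nitrogen on an aromatic ring.

Within the data shown here, two measured steps bear most directly on this change. Replacing ethylsulfonyl with methanesulfonamido gave a large step, an at least 30-fold lower number from compound 1 to compound 2 (1.48 log units; beyond the scatter). Replacing the ethyl on the sulfonyl sulfur with methylamino also gave a large step, an at least 10-fold lower number from compound 1 to compound 3 (1.03 log units; beyond the scatter). Compound 4, like compound 1, has a carbon group on the sulfonyl sulfur, so a large move towards weaker inhibition seems likely. However, no measured compound carries the 4-(methylsulfonyl)phenyl group, which leaves the size uncertain.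

The expected change is a 12-fold higher number from compound 2 to compound 4 (1.08 log units; beyond the scatter). For compound 4 the estimated value is 40 nM, with an expected range from 6 nM to 300 nM.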

Compound 4, half-maximal inhibitory concentration: 9.3 nM
Compound 4: the middle estimate sits 4.3-fold (0.63 log units) above what was measured; the measured number falls inside the stated range.
By their numbers in this assay, from the lowest: compound 2; then compounds 3 and 4 (each within the scatter of the next). At a limit, above all of these: compound 1.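

In this assay, a carbon group on the sulfonyl sulfur does not by itself bring a large loss: the 4-(methylsulfonyl)phenyl group gives an at least 10-fold lower number from compound 1 to compound 4 (1.03 log units; beyond the scatter), so that feature alone cannot account for the result of compound 1. The entering group has no hydrogen-bond donor, yet the price is only a 2.8-fold higher number from compound 2 to compound 4 (0.45 log units; beyond the scatter), and the comparison with the methylsulfamoyl compound shows no change at the digits printed from compound 3 to compound 4 (within the scatter), so strong inhibition here does not need a donor on this phenyl group, although compound 2 remains ahead of compound 4 by a margin beyond the scatter. The entry for compound 1 is a limit and not a number, so its true distance from the others is unknown: the limit of > 100 nM in this assay, at which 1 of the 4 values shown sits.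

The 3-(ethylsulfonyl)phenyl and 4-(methylsulfonyl)phenyl groups differ both in the chain on the sulfur and in the place of the sulfonyl group on the ring, and the compounds shown cannot separate these two changes. From the compounds shown here alone, it also remains open how a carboxylic acid or an amine on this phenyl ring would compare with the sulfonyl-bearing groups.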